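A Second Chlorine Enters the Aryl Ring of Compound 3

The source may hold more compounds than are shown below. What is called first, only, known or untested is meant among the compounds shown, and "the series" means these compounds.

Measured so far:
compound 1 `COc1cccc(/C=C2\CCC/C(=C\c3ccccc3Cl)C2=O)c1OC` gives 11700 nM;
compound 2 `COc1ccc(/C=C2\CCC/C(=C\c3cccc(OC)c3OC)C2=O)cc1` gives 16300 nM;
compound 3 `COc1ccc(/C=C2\CCC/C(=C\c3ccc(Cl)cc3)C2=O)cc1OC` gives 4800 nM.

These values come from a functional assay on HT-1080 cells (Homo sapiens) for cytotoxicity, read by MTT assay, with a stated time of 72 h; a higher number here means a weaker inhibitor, a lower number a stronger inhibitor. Compound 3 has the lowest number of the three; its nearest neighbour is compound 1 and the furthest is compound 2, both beyond the scatter. For the measured compounds named here, the only single-site step measured, a 1.4-fold higher number from compound 1 to compound 2 (0.14 log units; within the scatter), lies within the scatter and concerns a different exchange. Compound 4 `COc1ccc(/C=C2\CCC/C(=C\c3ccc(Cl)c(Cl)c3)C2=O)cc1OC` differs from compound 3 as follows: chloro in place of hydrogen on an aromatic carbon. Going by the values given here, no measured step matches this change, so the expectation rests on compound 3 alone and the step of a 1.4-fold lower number from compound 3 to compound 4 (0.14 log units; within the scatter) is expected to stay small, within the scatter. For compound 4 the estimate in this assay is 3500 nM, between 1500 nM and 8000 nM.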

Compound 4, half-maximal inhibitory concentration: 3100 nM
Beside the measured number, compound 4's estimate is 1.1-fold (0.05 log units) above it; measured number inside the range.
By their numbers in this assay, from the lowest: compounds 4 and 3 (each within the scatter of the next); then compounds 1 and 2 (each within the scatter of the next).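

A chloro group in place of hydrogen on this aromatic carbon, ortho to a chloro group, turns 4-chlorophenyl into 3,4-dichlorophenyl and gives a 1.5-fold lower number from compound 3 to compound 4 (0.19 log units; within the scatter) in this assay. This position therefore tolerates a second chlorine, and compound 3 and compound 4 cannot be told apart here. No measurement available explains this result. Going by these compounds, whether an amine or a carboxylic acid on this same carbon would also be tolerated remains open, as does whether the second chlorine would behave alike on the other compounds.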